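Taking the trifluoromethyl group off compound 3

The compounds below may be only part of what the source reports. "The series", "measured", "known", "first", "only" and "open" are said of these compounds alone.

In a functional assay on A549 cells (Homo sapiens) for inhibition, read by CCK-8 assay, with a stated time of 72 h, tested at 1 uM (on this read-out higher numbers stand for more inhibition of growth at the one concentration tested and lower numbers for less inhibition of growth), compound 3 (`CN(C)C(=O)c1cc2cnc(Nc3ccc(NC(=O)C4(C(=O)Nc5ccc(C(F)(F)F)cc5)CC4)cc3)nc2n1C1CCCC1`) gives -25.3% and so stands lowest of the three measured compounds. Compound 1 (`CN(C)C(=O)c1cc2cnc(Nc3ccc(NC(=O)C4(C(=O)Nc5ccc(Cl)cc5)CC4)cc3)nc2n1C1CCCC1`) gives 24.7% with chloro on the same aromatic carbon, and compound 2 (`COc1ccc(NC(=O)C2(C(=O)Nc3ccc(Nc4ncc5cc(C(=O)N(C)C)n(C6CCCC6)c5n4)cc3)CC2)cc1`) gives 74.4% with methoxy there. Compound 4 (`CN(C)C(=O)c1cc2cnc(Nc3ccc(NC(=O)C4(C(=O)Nc5ccccc5)CC4)cc3)nc2n1C1CCCC1`) has not yet been measured. It carries hydrogen in place of trifluoromethyl on an aromatic carbon, para to a large group (hydrogen in place of trifluoromethyl on an aromatic carbon).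

For the measured compounds named here, no measured step has hydrogen at this place, so the evidence is indirect. Trifluoromethyl in place of chloro gave a number 50 percentage points lower from compound 1 to compound 3 (beyond the scatter) and trifluoromethyl in place of methoxy gave a number 99.7 percentage points lower from compound 2 to compound 3 (beyond the scatter) and both steps are large. Methoxy in place of chloro gave a number 49.7 percentage points higher from compound 1 to compound 2 (beyond the scatter) as a further large step at the same place. All three substituents tested here therefore spread the numbers widely, and trifluoromethyl sits at the bottom of that spread. Removing it is expected to raise the number by a large amount, though how far remains uncertain. The estimated change is a number 65.3 percentage points higher from compound 3 to compound 4 (beyond the scatter) on this reasoning. In this assay compound 4 is estimated at 40% with a range of 5% to 75% expected.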

Compound 4, percent growth inhibition at one concentration: 75%
Estimate against measurement, compound 4: 35 percentage points below; the range from low to high includes it.
By their numbers in this assay, from the lowest: compound 3; then compound 1; then compounds 2 and 4 (each within the scatter of the next).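

In this assay, hydrogen in place of trifluoromethyl gives a number 100.3 percentage points higher from compound 3 to compound 4 (beyond the scatter), which shows that this para carbon needs no substituent for a high number. Hydrogen in place of chloro gives a number 50.3 percentage points higher from compound 1 to compound 4 (beyond the scatter), while hydrogen in place of methoxy gives a number 0.6 percentage points higher from compound 2 to compound 4 (within the scatter). For the compounds shown here, with the plain phenyl as a reference that the earlier compounds lacked, the spread among them reads differently: chloro and trifluoromethyl both stand with lower numbers than hydrogen, whereas methoxy cannot be told apart from hydrogen, so the high number of compound 2 owes nothing measurable to a gain from methoxy.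

As far as these compounds go, it remains open whether other groups on this carbon, such as an amine, a carboxylic acid or a simple methyl, would stay level with compound 2 and compound 4 or fall towards compound 1 and compound 3, and whether these differences would hold at other concentrations or in other cells. Nothing among the data shown accounts for why these substituents separate so widely.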